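A few compounds are considered here, and "the series" means these few. Any claim that something is new, unique, unknown or untested is made for them only; others in the source may bear on it.

- compound 1 `COc1ccc(OC)c(NC(=O)CCCCCCNC(=O)C(O)(O)C(F)(F)F)c1`: "not determined" (no result reported)
- compound 2 `COc1ccc(NC(=O)CCCCCCNC(=O)C(O)(O)C(F)(F)F)cc1`: "not determined" (no result reported)
- compound 3 `COc1ccc2sc(NC(=O)CCCCCCNC(=O)C(O)(O)C(F)(F)F)nc2c1`: 12300 nM

These compounds were examined in a functional assay on cells (Panel NCI-60 (60 carcinoma cell lines), Homo sapiens) for inhibition, read by colorimetric assay, with a stated time of 3 days; a lower number here means a stronger inhibitor of growth, a higher number a weaker inhibitor of growth. Compound 2 has no place on the numerical scale, since compound 2 gives "not determined" (no result reported). Compound 1 offers no comparison either, as compound 1 also gives "not determined" (no result reported). Among the compounds with values here, the only number available comes from compound 3, at 12300 nM, and compound 3 differs from compound 2 in more than one simple substituent.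

The next compound of interest is compound 4 `O=C(CCCCCCNC(=O)C(O)(O)C(F)(F)F)Nc1ccc(Br)cc1`, which has not yet been measured. The structural change is bromo in place of methoxy on an aromatic carbon, with bromo in place of methoxy on an aromatic carbon, para to a large group. Without a number for compound 2, the size of this step cannot be read from the data, and no direction is expected with confidence. The best guide is compound 3 at 12300 nM, and a result in the same broad region or somewhat weaker seems likely. For compound 4 the expected value is 30000 nM, with an estimated range from 10000 nM to 90000 nM.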

Compound 4, concentration for total growth inhibition: 20900 nM
Compound 4: middle estimate off by 1.4-fold (0.16 log units), on the high side; the measured number falls inside the stated range.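

Within the data shown here, compound 2 gives "not determined" (no result reported) in this assay and compound 4 gives 20900 nM so no step between these two compounds can be read. On these data alone, whether bromo in place of methoxy strengthens or weakens growth inhibition stays open. No supporting data bear on this result.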